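This account rests on a few compounds, and the source may have more. Where it says the series, first, only, none or still open, it means among the compounds named here.

For the measured compounds named here, in a physicochemical assay for solubility, measured as kinetic solubility, with a stated time of 1 h, at pH 7.4 (a lower number here means a less soluble compound, a higher number a more soluble compound), compound 1 `CC(=O)NC1=NN(c2ccc(Cl)c(Cl)c2)CC1` gives 31000 nM as the highest of the three numbers so far. Compound 3 `O=C(NC1=NN(c2ccc(Cl)c(Cl)c2)CC1)c1cccnc1F` comes nearest with 13000 nM and compound 2 `O=C(NC1=NN(c2ccc(Cl)c(Cl)c2)CC1)c1cccnc1` lies furthest away with 4000 nM on the same scale. Compound 4 `CC(=O)NC1=NN(c2ccc(Cl)c(Cl)c2)[C@H](C)C1` keeps the acetamido group of compound 1 and changes the core instead: methyl in place of hydrogen on a saturated ring carbon describes methyl in place of hydrogen on a saturated ring carbon.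

Going by the values given here, no measured step touches that ring carbon, so the evidence is indirect. Two steps replace the methyl on a carbonyl carbon: pyridin-3-yl gives a 7.8-fold lower number from compound 1 to compound 2 (0.89 log units; beyond the scatter) and 2-fluoropyridin-3-yl gives a 2.4-fold lower number from compound 1 to compound 3 (0.38 log units; beyond the scatter) as the result. The closest in kind is a replacement of hydrogen, fluoro on an aromatic carbon, which gives a 3.3-fold higher number from compound 2 to compound 3 (0.51 log units; beyond the scatter) in the opposite direction. All three are modest, and they do not agree on direction for a change at this new place.

The expected change is a 1.2-fold lower number from compound 1 to compound 4 (0.09 log units; within the scatter) and leans only slightly towards a lower number, so no step beyond the scatter is anticipated. For compound 4 the estimated value is 25000 nM within an expected range from 10000 nM to 60000 nM in this assay.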

Compound 4, solubility: 173000 nM
Beside the measured number, compound 4's estimate is 6.9-fold (0.84 log units) below it, and the stated range ends below it.
By their numbers in this assay, from the lowest: compound 2; then compound 3; then compound 1; then compound 4.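

In this assay, the step of a 5.6-fold higher number from compound 1 to compound 4 (0.75 log units; beyond the scatter) shows that this saturated ring carbon, next to the ring nitrogen, is a place where the number can move beyond the scatter, and that methyl in place of hydrogen moves it upward. Among the steps that start from compound 1, this is the only one that raises the number: the two changes on the carbonyl carbon, in compound 2 and compound 3, both lower it, so a change of just 1 heavy atom on the core has outweighed anything seen at the acetamido end. No measurement shown gives a reason for this rise.

The compounds shown leave open whether a longer chain such as ethyl, or a hydroxymethyl or an amine, on the same ring carbon would move the number in the same way, and whether the opposite arrangement of the methyl at that carbon would match compound 4. They also leave open whether the same methyl would raise the number when the acetamido group is replaced by the pyridin-3-yl carbonyl group of compound 2 or the 2-fluoropyridin-3-yl carbonyl group of compound 3.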